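From Methyl to Isopropyl on a Shared Core

The source may report more compounds than this note shows. Statements on the series, on what has been measured and on what is new or still open speak of the compounds shown alone.

Compound 2 `CCCC(=O)NC(c1ccc(C)cc1)c1cc(Cl)c2cccnc2c1O` is the point of departure. In a functional assay on A-375 cells (Homo sapiens) for antiproliferative activity, read by trypan blue exclusion and crystal violet staining, with a stated time of 72 h (a higher number here means a weaker inhibitor, a lower number a stronger inhibitor), compound 2 gives 120 nM. Compound 1 `CCCC(=O)NC(c1ccc(Cl)cc1)c1cc(Cl)c2cccnc2c1O` gives 120 nM, and the step of no change at the digits printed from compound 1 to compound 2 (within the scatter) shows nothing beyond the scatter, so compound 2 stands level with compound 1, the two together carrying the highest numbers of the three measured. Compound 3 `CCCCC(=O)NC(c1cc(Cl)cc(Cl)c1)c1ccc2cccnc2c1O` gives 90 nM, a number that lies within the scatter of compound 2. Compound 4 `CCCC(=O)NC(c1ccc(C(C)C)cc1)c1cc(Cl)c2cccnc2c1O` is not yet measured; it differs from compound 2 by isopropyl in place of methyl on an aromatic carbon. Within the data shown here, no measured step exchanges one alkyl group for a larger one on that ring; the only single-point step on hand, chloro to methyl, was flat. The data therefore give no ground for a shift beyond the scatter in this assay in either direction, and a flat outcome is expected. Compound 4 is estimated at 150 nM, within 60 nM to 400 nM, an expected step of a 1.3-fold higher number from compound 2 to compound 4 (0.10 log units; within the scatter).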

Compound 4, half-maximal inhibitory concentration: 120 nM
For compound 4 the middle estimate is 1.3-fold (0.10 log units) above the measured one; low and high end bracket the measured number.
By their numbers in this assay, from the lowest: compounds 3, 1, 2 and 4 (each within the scatter of the next).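

In this assay, among these compounds, replacing methyl with isopropyl on this aromatic carbon produces no change at the digits printed from compound 2 to compound 4 (within the scatter), the first evidence on a larger alkyl group at this position. The wider exchange of chloro for isopropyl produces no change at the digits printed from compound 1 to compound 4 (within the scatter), so chloro, methyl and isopropyl stand level here across compounds 1, 2 and 4, with the branched group adding nothing beyond the scatter. No independent data bear on why this position responds in this way.

Going by these compounds, all three groups carry no hydrogen-bond donors or acceptors, so it remains open whether an amine or a carboxylic acid at this carbon would keep the number level. On these data alone, it is equally open whether a longer chain or a phenyl ring would do so, or where on this ring the tolerance ends.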